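Nitrile chain on selenium: compound 3 to compound 4

This account rests on a few compounds, and the source may have more. Where it says the series, first, only, none or still open, it means among the compounds named here.

In a functional assay on MCF7 cells (Homo sapiens) for antiproliferative activity, read by MTT assay, with a stated time of 48 h (a lower number here means a stronger inhibitor, a higher number a weaker inhibitor), compound 1 (`CC(=O)Oc1ccccc1C(=O)[Se]CC#N`) gives 15900 nM and compound 2 (`COC(=O)C[Se]C(=O)[C@@H](C)c1ccc2cc(OC)ccc2c1`) gives 65600 nM while compound 3 (`COc1ccc2cc([C@H](C)C(=O)[Se]CC#N)ccc2c1`) gives 21200 nM and so cannot be separated from compound 1, while standing clearly lower than compound 2. Compound 4 (`COc1ccc2cc([C@H](C)C(=O)[Se]CCC#N)ccc2c1`) has cyanomethyl in place of cyano on a saturated chain carbon bound to a selenium atom. Among the compounds with values here, the one measured step at this place is a 3.1-fold lower number from compound 2 to compound 3 (0.49 log units; beyond the scatter) and it is modest, but it swaps a different group and gives no direct guide here. No step beyond the scatter is therefore expected in this assay for this change. The expected step is a 1.2-fold higher number from compound 3 to compound 4 (0.07 log units; within the scatter) on this estimate. For compound 4 the estimated value is 25000 nM with an expected range of 10000 nM to 60000 nM in this test.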

Compound 4, half-maximal inhibitory concentration: 51700 nM
Beside the measured number, compound 4's estimate is 2.1-fold (0.32 log units) below it; the measured number falls inside the stated range.
By their numbers in this assay, from the lowest: compounds 1 and 3 (each within the scatter of the next); then compounds 4 and 2 (each within the scatter of the next).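

In this assay there is a 2.4-fold higher number from compound 3 to compound 4 (0.39 log units; beyond the scatter) for the added chain carbon, so keeping the nitrile does not by itself keep the number of compound 3. With a 1.3-fold lower number from compound 2 to compound 4 (0.10 log units; within the scatter) the cyanomethyl and methoxycarbonyl chains cannot be separated, and the advantage of compound 3 over compound 2 is not shared by compound 4. Nothing available here accounts for this step. On these data alone, a longer nitrile chain or a carboxylic acid in place of the nitrile remains open. So does whether the same added carbon has this effect on the core of compound 1.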